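This account rests on a few compounds, and the source may have more. Where it says the series, first, only, none or still open, it means among the compounds named here.

Among the measured compounds shown here, compound 2, `COc1cc(-c2cc(C(=O)O)c3ccccc3n2)ccc1OCC(=O)Nc1ccc(C(F)(F)F)cc1`, gives 1.6 in a physicochemical assay for lipophilicity, using the shake flask method, in phosphate buffer, measured as octanol-water partition, at pH 7.4 (on this read-out higher numbers stand for higher lipophilicity and lower numbers for lower lipophilicity), the highest of the two numbers so far; compound 1, `COc1cc(-c2cc(C(=O)O)c3ccccc3n2)ccc1OCC(=O)Nc1ccccc1C(F)(F)F`, gives 1.3, and the step of a number 0.30 log units higher from compound 1 to compound 2 (within the scatter) stays within the scatter. Compound 3, `CCCCCCNC(=O)COc1ccc(-c2cc(C(=O)O)c3ccccc3n2)cc1OC`, differs from compound 2 by hexyl in place of 4-(trifluoromethyl)phenyl on an amide-type nitrogen. For the measured compounds named here, the only measured step, from compound 1 to compound 2, swaps one trifluoromethylphenyl for another and does not cover an aryl-to-chain exchange, so no measured comparison bears directly on this change. Compound 3 is therefore expected to stay close to compound 2, with a step of a number 0.10 log units lower from compound 2 to compound 3 (within the scatter) in this assay. The estimate for compound 3 is 1.5, ranging from 0.9 to 2.1.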

Compound 3, distribution coefficient: 1
The estimate for compound 3 lay 0.50 log units above the measured number; the range from low to high includes it.
By their numbers in this assay, from the lowest: compounds 3, 1 and 2 (each within the scatter of the next, the first and the last beyond it).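

Hexyl on the amide-type nitrogen gives the first step at this position that lies beyond the scatter in this assay, with a number 0.60 log units lower from compound 2 to compound 3 (beyond the scatter). Read from the other aryl amide, the same exchange gives a number 0.30 log units lower from compound 1 to compound 3 (within the scatter), so the result depends on which trifluoromethylphenyl group hexyl replaces. Nothing available explains this difference. Still open, from the compounds shown here alone, is whether a longer chain, a cyclohexyl ring or a chain ending in an amine on the same nitrogen would read like hexyl or like the two trifluoromethylphenyl groups.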